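Phenyl for ethyl on the ring nitrogen of a kinase inhibitor

The compounds below may be only part of what the source reports. "The series", "measured", "known", "first", "only" and "open" are said of these compounds alone.

Measured compounds:
Compound 1, `Cc1c(C(=O)Nc2ccc(Oc3ncnc4[nH]cc(-c5ccccc5)c34)c(F)c2)c(=O)c2ccccc2n1C`: > 10000 nM
Compound 2, `CCn1c(C)c(C(=O)Nc2ccc(Oc3ncnc4[nH]cc(-c5ccccc5)c34)c(F)c2)c(=O)c2cc(C)ccc21`: 150 nM

The two measured compounds share a common core and differ in the groups attached to it. In an assay on isolated protein for inhibition of tyrosine-protein kinase receptor UFO (Homo sapiens), read by FRET and Z'-LYTE, with a stated time of 1.5 h (on this read-out lower numbers stand for stronger inhibition and higher numbers for weaker inhibition), compound 1 is reported only as a limit, > 10000 nM, so no number is known for it; (the limit of > 10000 nM in this assay, at which 1 of the 2 values shown sits). Going by the values given here, compound 2, in the same this assay, gives 150 nM, the only actual number in this set, so it stands as the sole point of reference.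

Compound 3, `Cc1ccc2c(c1)c(=O)c(C(=O)Nc1ccc(Oc3ncnc4[nH]cc(-c5ccccc5)c34)c(F)c1)c(C)n2-c1ccccc1`, is not yet measured. It differs from compound 2 in one place: phenyl in place of ethyl on an aromatic nitrogen. The group that leaves is a short chain; the group that enters is an aromatic ring of carbon only, with no change in hydrogen-bond donors or acceptors and no charge.

Among the compounds with values here, no measured pair changes only at this position, so the size of the step is open. The expected step from compound 2 to compound 3 in this assay is a 1.3-fold lower number from compound 2 to compound 3 (0.10 log units; within the scatter), small and within the usual scatter in either direction. Compound 3 is therefore estimated at 120 nM, with a range from 25 nM to 900 nM.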

Compound 3, half-maximal inhibitory concentration: 620 nM
For compound 3 the middle estimate is 5.2-fold (0.71 log units) below the measured one; low and high end bracket the measured number.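

In this assay, the group on the aromatic nitrogen matters: phenyl in place of ethyl gives a 4.1-fold higher number from compound 2 to compound 3 (0.62 log units; beyond the scatter). Since a higher number here stands for weaker inhibition, the swap costs some inhibition without removing it, and compound 3 still gives a true measured value of 620 nM. Neither group carries hydrogen-bond donors or acceptors or a net charge, so this step is read on a swap between two groups built of carbon alone, a short chain of two heavy atoms and an aromatic ring of six.

This single step cannot separate the presence of a ring from the larger number of carbons, and a propyl chain or a benzyl group at the same nitrogen would help to tell those two apart. Compound 1 is reported only as a limit and differs from compound 2 in more than one place, so no further step can be read: the limit of > 10000 nM in this assay, at which 1 of the 3 values shown sits.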